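This account rests on a few compounds, and the source may have more. Where it says the series, first, only, none or still open, it means among the compounds named here.

In a functional assay on MDA-MB-231 cells (Homo sapiens) for antiproliferative activity, read by MTT assay, with a stated time of 48 h (on this read-out higher numbers stand for weaker inhibition and lower numbers for stronger inhibition), compound 1 `C=CS(=O)(=O)N1CCN(c2ncnc3sc(-c4ccc(C#N)cc4)cc23)CC1` gives 8050 nM and compound 2 `C=CS(=O)(=O)N1CCN(c2ncnc3sc(-c4ccc(F)nc4)cc23)CC1` gives 16000 nM. Within the data shown here, these are the only two numbers in the set, and they are separated by a 2.0-fold higher number from compound 1 to compound 2 (0.30 log units; within the scatter). Compound 3 `C=CS(=O)(=O)N1CCN(c2ncnc3sc(C4=CCCCC4)cc23)CC1` reports only a limit, > 50000 nM. Against that limit, the steps are an at least 6.2-fold higher number from compound 1 to compound 3 (0.79 log units; beyond the scatter) and an at least 3.1-fold higher number from compound 2 to compound 3 (0.49 log units; beyond the scatter).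

Compound 4 `C=CS(=O)(=O)N1CCN(c2nc(OCC3CCCCN3C)nc3sc(-c4ccc(C#N)cc4)cc23)CC1` keeps the 4-cyanophenyl group of compound 1 and differs by (1-methylpiperidin-2-yl)methoxy in place of hydrogen on an aromatic carbon, between two ring nitrogen atoms. All three measured steps exchange the group at the 4-cyanophenyl site, and none alters that carbon. Among the measured compounds shown here, they therefore offer only a rough scale of step size in this assay and no direct precedent for the new group. A modest move toward a lower number is expected, with wide uncertainty. The expected step is a 2.3-fold lower number from compound 1 to compound 4 (0.36 log units; beyond the scatter). For compound 4 the estimate is 3500 nM, with an expected range from 800 nM to 14000 nM.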

Compound 4, half-maximal inhibitory concentration: 3180 nM
Compound 4: the middle estimate sits 1.1-fold (0.04 log units) above what was measured, and the stated range covers the measured number.
By their numbers in this assay, from the lowest: compound 4; then compounds 1 and 2 (each within the scatter of the next). At a limit, above all of these: compound 3.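

In this assay, the aromatic carbon between two ring nitrogen atoms accepts (1-methylpiperidin-2-yl)methoxy in place of hydrogen, with a 2.5-fold lower number from compound 1 to compound 4 (0.40 log units; beyond the scatter). Among these compounds, all earlier steps exchange the group at the 4-cyanophenyl site, so this is the first sign that the second position can carry a substituent, here one with a six-membered non-aromatic ring, without loss of inhibition on this read-out. The only limit in the set belongs to compound 3, while compound 4 stays a measured number: the limit of > 50000 nM in this assay, at which 1 of the 4 values shown sits.

Which part of the new group carries the step stays open: a plain methoxy, or a piperidine with a hydrogen in place of the nitrogen methyl, would separate the ether from the ring and its amine. On these data alone, whether the same change holds with 6-fluoropyridin-3-yl or cyclohex-1-en-1-yl at the other site is also open.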